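A few compounds are considered here, and "the series" means these few. Any claim that something is new, unique, unknown or untested is made for them only; others in the source may bear on it.

Measured so far in a functional assay, with a stated time of 150 min, tested at 5 ug/mL; a higher number here means a stronger effect of the compound at the concentration tested, a lower number a weaker effect:
- compound 1, `COC(=O)c1c(Nc2ccccc2)sc(C(=O)c2ccc(OC)cc2)c1C`: 13.3%
- compound 2, `COC(=O)c1c(Nc2ccccc2)sc(C(=O)c2ccc(C)cc2)c1C`: 2.08%
- compound 3, `COc1ccc(C(=O)c2sc(Nc3ccc(C)cc3)c(C(=O)O)c2C)cc1`: "not active" (no number reported)

Compound 1 and compound 2 share one core and differ at a single place, (methoxy in place of methyl on an aromatic carbon). Across that place the read-out moves a number 11.2 percentage points higher from compound 2 to compound 1 (beyond the scatter). Compound 3 carries a different core; how it differs from the core of compound 2 is not broken down here. In this assay compound 3 gives "not active" (no number reported), so no number stands for it.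

Compound 4, `COc1ccc(Nc2sc(C(=O)c3ccc(OC)cc3)c(C)c2C(=O)O)cc1`, is not yet measured. It differs from compound 3 by methoxy in place of methyl on an aromatic carbon. The place is the same as in the step from compound 2 to compound 1, though the ring that carries it reads, one bond further out, (4-methylphenyl)amino to (4-methoxyphenyl)amino rather than 4-methylphenyl to 4-methoxyphenyl; the change is therefore taken as the same change, made on a different core.

Among the measured compounds shown here, for compound 4 in this assay a modest step upward from compound 3 is expected, of roughly the size seen in a number 11.2 percentage points higher from compound 2 to compound 1 (beyond the scatter), because a number 11.2 percentage points higher from compound 2 to compound 1 (beyond the scatter) is the only measured instance of this change; compound 3 itself enters without a number. The expected value for compound 4 is 8%, with a plausible range from 0% to 22%, and a fair chance that this assay again reports no number.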

Compound 4, a percentage reported as activity, at one concentration (the size of the read-out at that concentration, not a potency): 20.2%
Estimate against measurement, compound 4: 12.2 percentage points below, within the range that was stated.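

No step can be read from compound 3 to compound 4: in this assay compound 3 gives "not active" (no number reported), which leaves nothing to set against compound 4 at 20.2%. The compounds shown leave open how far methoxy in place of methyl moves the read-out on the core of compound 3. No measured evidence bears on this result.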